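Mirror-image switch of a nonyl iminosugar alpha-glucosidase inhibitor

This account rests on a few compounds, and the source may have more. Where it says the series, first, only, none or still open, it means among the compounds named here.

Measured compounds:
compound 1 `OC[C@@]1(c2ccc(F)cc2)NC[C@@H](O)[C@@H]1O`, 714000 nM
compound 2 `CCCCCCCCC[C@@]1(CO)NC[C@H](O)[C@H]1O`, 3700 nM
compound 3 `OC[C@]1(c2ccccc2)NC[C@H](O)[C@H]1O`, 630 nM

In an assay on isolated protein for inhibition of lysosomal alpha-glucosidase (Homo sapiens) (on this read-out lower numbers stand for stronger inhibition and higher numbers for weaker inhibition), compound 2 sits second highest of the three numbers: compound 3 lies a clear step below it, and compound 1, the weakest here, lies far above it. Compound 4 `CCCCCCCCC[C@]1(CO)NC[C@@H](O)[C@@H]1O` keeps every atom and bond of compound 2 but is its mirror image: the two compounds have the same atoms and bonds and differ only in configuration as drawn: 3 of 3 stereo elements differ (all stereocentres are inverted: mirror images); a stereocentre at a saturated ring carbon is drawn S in compound 2 and R in compound 4; a stereocentre at a saturated ring carbon is drawn S in compound 2 and R in compound 4; a stereocentre at a saturated ring carbon is drawn S in compound 2 and R in compound 4. Going by the values given here, no measured pair shows this kind of switch, so its size is not known from the data; inversion of all stereocentres in a sugar mimic is generally expected to weaken binding, and a large step toward weaker inhibition is expected here. Compound 4 is therefore estimated at 200000 nM, with a range of 30000 nM to 1000000 nM, an expected step of a 54-fold higher number from compound 2 to compound 4 (1.73 log units; beyond the scatter).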

Compound 4, half-maximal inhibitory concentration: 130000 nM
Compound 4: the middle estimate sits 1.5-fold (0.19 log units) above what was measured; low and high end bracket the measured number.
By their numbers in this assay, from the lowest: compound 3; then compound 2; then compound 4; then compound 1.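

In this assay inverting all three stereocentres of the nonyl compound gives a 35-fold higher number from compound 2 to compound 4 (1.55 log units; beyond the scatter), so the set now puts a size on configuration alone. Going by these compounds alone, no earlier pair isolated this change, and the loss can be assigned to the spatial arrangement, because nothing else separates the two compounds: the fact that compounds 2 and 4 differ only in the configuration as drawn.

Whether inverting just one of the three stereocentres would account for part or all of this step stays open. So does whether a chain ending in an amine, in place of the nonyl chain, would show an equally large step.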